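A few compounds are considered here, and "the series" means these few. Any claim that something is new, unique, unknown or untested is made for them only; others in the source may bear on it.

Measured compounds:
compound 1 `CC(C)(C)c1ccc(CNCCCNS(=O)(=O)c2cc(C(F)(F)F)cc(C(F)(F)F)c2)cc1` — 2500 nM
compound 2 `COc1ccc(CNCCCNS(=O)(=O)c2cc(C(F)(F)F)cc(C(F)(F)F)c2)cc1OC` — 2400 nM

In a functional assay on NCI-H460 cells (Homo sapiens) for inhibition, read by MTT assay, with a stated time of 72 h (on this read-out higher numbers stand for weaker inhibition of growth and lower numbers for stronger inhibition of growth), compound 1 gives 2500 nM and compound 2 gives 2400 nM. Compound 2 has the lower of the two numbers, but the gap to compound 1 is within the scatter, so the two stand level. Within the data shown here, the one measured step, a 1.0-fold lower number from compound 1 to compound 2 (0.02 log units; within the scatter), exchanges the group on a saturated chain carbon bound to an amine nitrogen and leaves the read-out unchanged beyond the scatter.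

Compound 3 `O=S(=O)(NCCCNCc1ccc(Br)cc1)c1cc(C(F)(F)F)cc(C(F)(F)F)c1` is not yet measured. It differs from compound 2 in the same place: 4-bromophenyl in place of 3,4-dimethoxyphenyl on a saturated chain carbon bound to an amine nitrogen. The step from compound 1 to compound 2 bears on this change, since it also swaps the aryl group at that position, and it was flat. Among the measured compounds shown here, no measured step tests 4-bromophenyl itself, so the expectation leans on that single flat step. Compound 3 is expected to stay near compound 2, with no change at the digits printed from compound 2 to compound 3 (within the scatter) as the expected step. The estimate for compound 3 in this assay is 2400 nM, in the range 900 nM to 6500 nM.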

Compound 3, concentration for 50% growth inhibition: 2500 nM
Beside the measured number, compound 3's estimate is 1.0-fold (0.02 log units) below it; low and high end bracket the measured number.
By their numbers in this assay, from the lowest: compounds 2, 1 and 3 (each within the scatter of the next).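

In this assay, 4-bromophenyl and 3,4-dimethoxyphenyl on a saturated chain carbon bound to an amine nitrogen stand level, with a 1.0-fold higher number from compound 2 to compound 3 (0.02 log units; within the scatter), even though the 2 hydrogen-bond acceptors counted on 3,4-dimethoxyphenyl are absent from 4-bromophenyl. Bromo in place of tert-butyl on an aromatic carbon also stays within the scatter, with no change at the digits printed from compound 1 to compound 3 (within the scatter), so the three aryl groups now stand level at this position and the flat reading no longer rests on a single pair. Nothing measured here accounts for this flat reading.

The compounds shown leave open whether any group at this position separates beyond the scatter, such as a pyridine ring or a phenyl ring carrying a carboxylic acid. They also leave open whether the level reading would hold with a longer chain in the shared core or with chloro in place of trifluoromethyl.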